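Replacing a carbamate with an amide on the pyrrolidine nitrogen

The source may hold more compounds than are shown below. What is called first, only, known or untested is meant among the compounds shown, and "the series" means these compounds.

Compound 1 `O=C(CN1CCNCC1)N1CCC(NS(=O)(=O)c2cc(S(=O)(=O)c3ccccc3)ccc2C(F)(F)F)CC1`: in an assay on isolated protein for binding affinity to secreted frizzled-related protein 1 (Homo sapiens), read by fluorescence (on this read-out lower numbers stand for stronger inhibition and higher numbers for weaker inhibition), compound 1 gives 140 nM.
Compound 2 `CC(C)(C)OC(=O)N1CCC[C@H]1C(=O)N1CCC(NS(=O)(=O)c2cc(S(=O)(=O)c3ccccc3)ccc2C(F)(F)F)CC1`: in this assay compound 2 gives 60 nM.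
Compound 3 `CC(C)(C)OC(=O)N1C(=O)CC[C@H]1C(=O)N1CCC(NS(=O)(=O)c2cc(S(=O)(=O)c3ccccc3)ccc2C(F)(F)F)CC1`: in this assay compound 3 gives 130 nM.

Compound 2 holds the lowest of the three numbers in this assay; compound 3 lies a 2.3-fold lower number from compound 1 to compound 2 (0.37 log units; beyond the scatter) away only in the sense that compound 1 does, the step of a 2.3-fold lower number from compound 1 to compound 2 (0.37 log units; beyond the scatter) being a modest one, and compound 3 sits between the two on the values shown. Compound 4 `CC(C)(C)C(=O)N1CCC[C@H]1C(=O)N1CCC(NS(=O)(=O)c2cc(S(=O)(=O)c3ccccc3)ccc2C(F)(F)F)CC1` differs from compound 2 by tert-butyl in place of tert-butoxy on a carbonyl carbon. Among the measured compounds shown here, no measured step touches this position: the one step that is known changes the whole group on that carbonyl carbon, and compound 3 alters the pyrrolidine ring rather than the tert-butoxy group. With nothing pointing either way, the expected step of a 1.2-fold higher number from compound 2 to compound 4 (0.07 log units; within the scatter) is small and within the scatter. Compound 4 is therefore estimated at 70 nM, within a range from 30 nM to 170 nM.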

Compound 4, half-maximal inhibitory concentration: 40 nM
For compound 4 the middle estimate is 1.8-fold (0.24 log units) above the measured one, and the stated range covers the measured number.
By their numbers in this assay, from the lowest: compounds 4 and 2 (each within the scatter of the next); then compounds 3 and 1 (each within the scatter of the next).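

In this assay, tert-butyl in place of tert-butoxy on this carbonyl carbon gives a 1.5-fold lower number from compound 2 to compound 4 (0.18 log units; within the scatter), so the oxygen of the tert-butoxy group can go without a step beyond the scatter. The acyl group on the pyrrolidine nitrogen is thus not tied to the carbamate form in these two compounds. The second step, a 3.5-fold lower number from compound 1 to compound 4 (0.54 log units; beyond the scatter), shows that the 1-((tert-butyl)carbonyl)pyrrolidin-2-yl group, like the 1-(tert-butoxycarbonyl)pyrrolidin-2-yl group of compound 2, stands apart from the (piperazin-1-yl)methyl group of compound 1. No measurement given here explains either step.

From the compounds shown here alone, what a methyl, a cyclopropyl or a dimethylamino group on this carbonyl carbon would give remains open. So does the result for the free pyrrolidine amine, with no acyl group on that nitrogen.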